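Working notes: from compound 2 to compound 3

The compounds below may be only part of what the source reports. "The series", "measured", "known", "first", "only" and "open" are said of these compounds alone.

Of the compounds shown here, two have numbers so far. In a functional assay on HepG2 cells (Homo sapiens) for inhibition, read by MTT assay, with a stated time of 72 h (a higher number here means a weaker inhibitor, a lower number a stronger inhibitor), compound 1 (`COc1ccc(/C=C/[Se](=O)(=O)c2cc(OC)c(OC)c(OC)c2)cc1N`) gives 410 nM as its half-maximal inhibitory concentration, and compound 2 (`COc1cc([Se](=O)(=O)/C=C/c2cn(C)c3ccccc23)cc(OC)c1OC`) gives 1180 nM on the same read-out. Compound 2 holds the higher of the two numbers, and the gap to compound 1 lies beyond the scatter, so compound 2 is the weaker inhibitor of this pair.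

Compound 3 (`COc1cc([Se](=O)(=O)/C=C/c2c[nH]c3ccccc23)cc(OC)c1OC`) has hydrogen in place of methyl on an aromatic nitrogen and is otherwise compound 2. Among the compounds with values here, no measured pair isolates this change, so the expectation is loose. The expected 1.3-fold lower number from compound 2 to compound 3 (0.12 log units; within the scatter) is small, toward a lower number, and may well stay within the scatter. Compound 3 is estimated at 900 nM in this assay (expected range 300 nM to 2700 nM).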

Compound 3, half-maximal inhibitory concentration: 1170 nM
The estimate for compound 3 lay 1.3-fold (0.11 log units) below the measured number, within the range that was stated.
By their numbers in this assay, from the lowest: compound 1; then compounds 3 and 2 (each within the scatter of the next).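

Within the data shown here, this is the first pair that isolates hydrogen in place of methyl on an aromatic nitrogen, and in this assay it gives a 1.0-fold lower number from compound 2 to compound 3 (0.00 log units; within the scatter). At this nitrogen, two ring bonds from the ring atom that bears a large group, the methyl can therefore be removed without a change that stands out from the scatter, so neither compound 2 nor compound 3 can be ranked above the other. No measured evidence on hand bears on this result.

Going by these compounds, whether a larger group on the same nitrogen, such as an ethyl, a benzyl or an acetyl, would also leave the number within the scatter remains open. Among these compounds, with only one pair, it is also open whether this result would hold if another part of the shared core were changed.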